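A few compounds are considered here, and "the series" means these few. Any claim that something is new, unique, unknown or untested is made for them only; others in the source may bear on it.

Compound 1 `O=C(NCc1cn(Cc2ccc(F)cc2)nn1)c1cn(-c2ccccc2)nc1-c1ccccc1`: 7000 nM
Compound 2 `O=C(NCc1cn(Cc2ccc(C(F)(F)F)cc2)nn1)c1cn(-c2ccccc2)nc1-c1ccccc1`: 840 nM
Compound 3 `COc1ccc(Cn2cc(CNC(=O)c3cn(-c4ccccc4)nc3-c3ccccc3)nn2)cc1OC`: 12600 nM

In a functional assay on MCF7 cells (Homo sapiens) for antiproliferative activity, read by sulforhodamine B assay, with a stated time of 48 h (on this read-out higher numbers stand for weaker inhibition of growth and lower numbers for stronger inhibition of growth), compound 3 gives the highest of the three numbers; the gap a 1.8-fold higher number from compound 1 to compound 3 (0.26 log units; within the scatter) stays within the scatter, whereas a 15-fold higher number from compound 2 to compound 3 (1.18 log units; beyond the scatter) lies well beyond it. Compound 4 `COc1cc(Cn2cc(CNC(=O)c3cn(-c4ccccc4)nc3-c3ccccc3)nn2)cc(OC)c1OC` differs from compound 3 by methoxy in place of hydrogen on an aromatic carbon. Within the data shown here, no measured step adds a methoxy group alone; the two steps that bring in methoxy groups, a 1.8-fold higher number from compound 1 to compound 3 (0.26 log units; within the scatter) and a 15-fold higher number from compound 2 to compound 3 (1.18 log units; beyond the scatter), both raised the number. A further methoxy is therefore expected to leave the number roughly unchanged or move it slightly upward, with the step of a 1.2-fold higher number from compound 3 to compound 4 (0.08 log units; within the scatter) estimated. Compound 4 is expected to give about 15000 nM, within 6000 nM to 40000 nM.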

Compound 4, concentration for 50% growth inhibition: > 100000 nM
Compound 4: no number, only a limit (the forecaster's own chance of this, stated with the estimate: 10%); at least 6.6-fold (0.82 log units) between middle value and limit.
By their numbers in this assay, from the lowest: compound 2; then compounds 1 and 3 (each within the scatter of the next). At a limit, above all of these: compound 4.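

In this assay compound 4 gives a limit and not a number: the limit of > 100000 nM in this assay, at which 1 of the 4 values shown sits.

This position is therefore not indifferent to substitution: the single added methoxy gives an at least 7.9-fold higher number from compound 3 to compound 4 (0.89 log units; beyond the scatter), whereas the change from 4-fluorophenyl to 3,4-dimethoxyphenyl gave only a 1.8-fold higher number from compound 1 to compound 3 (0.26 log units; within the scatter). The 3,4,5-trimethoxyphenyl group also gives an at least 14-fold higher number from compound 1 to compound 4 (1.15 log units; beyond the scatter) and an at least 110-fold higher number from compound 2 to compound 4 (2.07 log units; beyond the scatter).

Going by these compounds, whether a hydroxy group or an amine on this same aromatic carbon would give a measurable number remains open. So does whether a smaller group, such as methyl or chloro, would be tolerated there.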